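Swapping an aryl group on a thiazole acetic acid core

The compounds below may be only part of what the source reports. "The series", "measured", "known", "first", "only" and "open" are said of these compounds alone.

Measured compounds:
compound 1 `O=C(O)Cc1sc(NCc2ccccc2)nc1-c1ccc(Cl)cc1` gives 2300 nM
compound 2 `O=C(O)Cc1sc(C(c2ccccc2)c2ccc(F)cc2)nc1-c1ccc(Cl)cc1` gives 36 nM
compound 3 `NS(=O)(=O)c1cccc(-c2nc(C(c3ccc(F)cc3)c3ccc(F)cc3)sc2CC(=O)O)c1` gives 710 nM

These values come from an in vitro functional assay on HEK285-7 cells for antagonist activity at prostaglandin D2 receptor 2 (Homo sapiens), read by BRET and beta-arrestin recruitment; a higher number here means a weaker inhibitor, a lower number a stronger inhibitor. Compound 3 stands second highest of the three: its number is lower than that of compound 1 and far higher than that of compound 2, and both gaps lie beyond the usual scatter. Compound 4 `O=C(O)Cc1sc(C(c2ccc(F)cc2)c2ccc(F)cc2)nc1-c1ccnc(N2CCCC2)c1` has not yet been measured. It differs from compound 3 in one place: 2-(pyrrolidin-1-yl)pyridin-4-yl in place of 3-sulfamoylphenyl on an aromatic carbon. For the measured compounds named here, no measured pair shows this exact change, so the step is uncertain. Still, compound 4 is expected to give a lower number than compound 3, the step of a 4.7-fold lower number from compound 3 to compound 4 (0.68 log units; beyond the scatter) being beyond the scatter. The estimate for compound 4 in this assay is 150 nM, with a range from 40 nM to 600 nM.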

Compound 4, half-maximal inhibitory concentration: > 100000 nM
Compound 4 was reported as a limit (the forecaster's own chance of this, stated with the estimate: 2%); at least 660-fold (2.82 log units) between middle value and limit.
By their numbers in this assay, from the lowest: compound 2; then compound 3; then compound 1. At a limit, above all of these: compound 4.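

In this assay, placing 2-(pyrrolidin-1-yl)pyridin-4-yl instead of 3-sulfamoylphenyl on this aromatic carbon, next to the ring nitrogen, gives an at least 140-fold higher number from compound 3 to compound 4 (2.14 log units; beyond the scatter). The result for compound 4 is a limit and not a number: the limit of > 100000 nM in this assay, at which 1 of the 4 values shown sits. For the compounds shown here, this position therefore does not accept every six-membered aromatic ring, a sharp sensitivity that the earlier compounds did not reveal.

The compounds shown leave open whether the pyrrolidine ring or the pyridine ring accounts for this change. A plain pyridin-4-yl group or a 3-(pyrrolidin-1-yl)phenyl group at this position would help separate the two.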